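The compounds below may be only part of what the source reports. "The series", "measured", "known", "first", "only" and "open" are said of these compounds alone.

Of the compounds shown here, three have been measured so far in a functional assay on A549 cells (Homo sapiens) for inhibition; a higher number here means a weaker inhibitor, a lower number a stronger inhibitor. Compound 1 `COc1ccc(/C=C/c2ccc3ccccc3c2)cc1[N+](=O)[O-]` gives > 5000 nM, which is a limit and not a number. Compound 2 `COc1cc(/C=C/c2ccc3ccccc3c2)cc([N+](=O)[O-])c1OC` gives > 10000 nM, again a limit of the assay. For the measured compounds named here, compound 3 `COc1cc(/C=C\c2ccc3ccccc3c2)cc([N+](=O)[O-])c1OC` gives 590 nM, the only true number among the three. Compound 2 thus offers no number to start from.

The next structure is compound 4 `COc1cc(/C=C/c2ccc3ccccc3c2)cc(NC(C)=O)c1OC`, which keeps the configuration drawn for compound 2 and exchanges a single group: acetamido in place of nitro on an aromatic carbon. In words, acetamido stands in place of nitro on an aromatic carbon.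

Neither measured step involves this exchange. Going by the values given here, the first is a step that the two limits leave unreadable from compound 1 to compound 2, and it concerns methoxy in place of hydrogen. The second is an at least 16-fold lower number from compound 2 to compound 3 (1.22 log units; beyond the scatter), a large step that comes with the fact that compounds 2 and 3 differ only in the configuration as drawn. Compound 4 does not share the configuration of compound 3, so that gain is not expected to carry over.

The expectation therefore rests on compound 2 at > 10000 nM, a limit. No step beyond the scatter is expected in this assay, and the estimated change is a number no higher from compound 2 to compound 4 (the limit leaves the size open). For compound 4 the estimated value is 10000 nM, with a range of 2500 nM to 30000 nM.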

Compound 4, half-maximal inhibitory concentration: > 5000 nM
Compound 4 was reported as a limit (the forecaster's own chance of this, stated with the estimate: 65%); the middle value does not contradict the limit.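

In this assay compound 4 gives > 5000 nM, which is a limit and not a number. Compound 2 is also reported only as a limit, so no step can be read between compound 2 and compound 4. The compounds shown leave open what acetamido in place of nitro does when the double bond is drawn Z, as in compound 3.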